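This account rests on a few compounds, and the source may have more. Where it says the series, first, only, none or still open, it means among the compounds named here.

Compound 1 `CO[C@H]1/C=C/C[C@H](C)[C@@H](C)S(=O)(=O)NC(=O)c2ccc3c(c2)N(C[C@@H]2CC[C@H]21)C[C@@]1(CCCc2cc(Cl)ccc21)CO3` | 240 nM
Compound 2 `C[C@@H]1[C@@H](C)C/C=C/[C@H](O)[C@@H]2CC[C@H]2CN2C[C@@]3(CCCc4cc(Cl)ccc43)COc3ccc(cc32)C(=O)NS1(=O)=O` | 140 nM

Among the compounds with values here, in a functional assay on OPM-2 cells (Homo sapiens) for inhibition, with a stated time of 24 h, in the presence of a further agent that is not named here (a higher number here means a weaker inhibitor, a lower number a stronger inhibitor), compound 2 gives 140 nM and lies within the scatter of compound 1, the only other compound measured. Compound 3 `C[C@@H]1[C@@H](C)C/C=C/[C@H](OCC(=O)O)[C@@H]2CC[C@H]2CN2C[C@@]3(CCCc4cc(Cl)ccc43)COc3ccc(cc32)C(=O)NS1(=O)=O` differs from compound 2 at one place (carboxymethyl in place of hydrogen on an oxygen on a saturated carbon), with carboxymethyl in place of hydrogen on an oxygen on a saturated carbon. Within the data shown here, one measured step bears on that oxygen (a 1.7-fold lower number from compound 1 to compound 2 (0.23 log units; within the scatter)), and it stays within the scatter. Among the measured compounds shown here, it exchanges only methyl for hydrogen, however, and no measured compound carries anything like carboxymethyl, so it is a weak guide. A moderately higher number is therefore expected in this assay, though with much doubt over its size. The expected step is a 3.6-fold higher number from compound 2 to compound 3 (0.55 log units; beyond the scatter) and could prove smaller. For compound 3 the estimate is 500 nM and the expected range runs from 120 nM to 2500 nM in this measure.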

Compound 3, half-maximal inhibitory concentration: 1100 nM
Compound 3: the middle estimate sits 2.2-fold (0.34 log units) below what was measured; measured number inside the range.
By their numbers in this assay, from the lowest: compounds 2 and 1 (each within the scatter of the next); then compound 3.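

In this assay, the oxygen on a saturated carbon proves sensitive to what it carries: methyl and hydrogen there lie within the scatter of each other, but carboxymethyl in place of hydrogen gives a 7.9-fold higher number from compound 2 to compound 3 (0.90 log units; beyond the scatter). Set against the compound with methyl on that oxygen, the change reads a 4.6-fold higher number from compound 1 to compound 3 (0.66 log units; beyond the scatter), so the rise stands beyond the scatter from both neighbours, and hydroxy to carboxymethoxy is the first change at this position with a clear effect. Nothing available explains this rise.

The compounds shown leave open whether the higher number goes with the carboxylic acid itself or with the added chain; a methyl ester or a primary amide of that acid on the same oxygen would separate the two. From the compounds shown here alone, how an amine at the end of such a chain, or a longer chain carrying the acid, would read also stays open.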